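Estimating Compound 4 After Relocating the Chlorine

The source may hold more compounds than are shown below. What is called first, only, known or untested is meant among the compounds shown, and "the series" means these compounds.

Three compounds have been measured in a functional assay on NCI-H460 cells (Homo sapiens) for inhibition, read by MTT assay, with a stated time of 72 h; on this read-out higher numbers stand for weaker inhibition and lower numbers for stronger inhibition:

Compound 1, `COc1cc(NC(C)CCCNC(=O)Nc2ccc(C(F)(F)F)cc2)c2ncccc2c1`, gives 24000 nM.
Compound 2, `COc1cc(NC(C)CCCNC(=O)NNC(=O)Nc2cccc(C(F)(F)F)c2)c2ncccc2c1`, gives 20000 nM.
Compound 3, `COc1cc(NC(C)CCCNC(=O)NNC(=O)Nc2cccc(Cl)c2)c2ncccc2c1`, gives 32000 nM.

Compound 3 shows the highest of the three numbers, yet the steps of a 1.3-fold higher number from compound 1 to compound 3 (0.12 log units; within the scatter) and a 1.6-fold higher number from compound 2 to compound 3 (0.20 log units; within the scatter) both sit within the scatter, so the three compounds cannot be separated on these data.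

Compound 4, `COc1cc(NC(C)CCCNC(=O)NNC(=O)Nc2ccc(Cl)cc2)c2ncccc2c1`, differs from compound 3 in one place: 4-chlorophenyl in place of 3-chlorophenyl on an amide-type nitrogen. Going by the values given here, no measured step moves a chlorine within the same ring, so the evidence is indirect. The step of a 1.6-fold higher number from compound 2 to compound 3 (0.20 log units; within the scatter) changes the group carried on that ring and stays within the scatter, and the step of a 1.3-fold higher number from compound 1 to compound 3 (0.12 log units; within the scatter) exchanges the whole end of the molecule, including which ring position carries its substituent, and also stays within the scatter. Nothing here suggests that this region of the molecule shifts the number beyond the scatter.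

Compound 4 is therefore expected to give about 30000 nM, with a likely range from 12000 nM to 75000 nM, and the expected step of a 1.1-fold lower number from compound 3 to compound 4 (0.03 log units; within the scatter) is within the scatter.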

Compound 4, half-maximal inhibitory concentration: 63000 nM
The estimate for compound 4 lay 2.1-fold (0.32 log units) below the measured number; the range from low to high includes it.
By their numbers in this assay, from the lowest: compounds 2, 1, 3 and 4 (each within the scatter of the next, the first and the last beyond it).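

Going by these compounds alone, compound 4 gives the first direct look at moving the chlorine around the ring in this assay, and a 2.0-fold higher number from compound 3 to compound 4 (0.29 log units; within the scatter) shows that this change alone cannot be told apart from repeat-measurement noise. Compound 4 does, however, open the first gaps beyond the scatter in this set: a 3.2-fold higher number from compound 2 to compound 4 (0.50 log units; beyond the scatter) with 4-chlorophenyl in place of 3-(trifluoromethyl)phenyl, and a 2.6-fold higher number from compound 1 to compound 4 (0.42 log units; beyond the scatter) with ((4-chlorophenyl)carbamoyl)amino in place of 4-(trifluoromethyl)phenyl. Both steps are modest and point towards weaker inhibition, so changes in this region can move the number measurably, even though the chlorine shift alone does not clearly do so.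

From the compounds shown here alone, it remains open whether 3-(trifluoromethyl)phenyl and 4-(trifluoromethyl)phenyl would differ in the same way as the two chlorophenyl groups if both sat on the same end of the molecule. Going by these compounds, it is also open whether an amine or a carboxylic acid on this ring would bring the number down rather than up. Nothing available here explains why these numbers differ.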